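From 4-methoxyphenyl to 2,3-dichlorophenyl on a shared core

The source may report more compounds than this note shows. Statements on the series, on what has been measured and on what is new or still open speak of the compounds shown alone.

In an ADME assay on NHDF cells (Homo sapiens) for cytotoxicity, read by MTT assay, with a stated time of 72 h (a lower number here means a stronger inhibitor, a higher number a weaker inhibitor), compound 1 `COc1ccc(/C=C2\CCC/C(=C\c3ccc(Cl)cc3)C2=O)cc1OC` gives 11200 nM and compound 2 `COc1ccc(/C=C2\CCC/C(=C\c3ccc(OC)c(OC)c3)C2=O)cc1` gives 30900 nM, the higher of the two numbers. Compound 3 `COc1ccc(/C=C2\CCC/C(=C\c3cccc(Cl)c3Cl)C2=O)cc1OC` departs from compound 2 in one place: 2,3-dichlorophenyl in place of 4-methoxyphenyl on a double-bonded chain carbon bound to a double-bonded ring carbon. The new group is 2,3-dichlorophenyl in place of 4-methoxyphenyl on a double-bonded chain carbon bound to a double-bonded ring carbon. Among the measured compounds shown here, only one measured step bears on this change, with methoxy in place of chloro on an aromatic carbon, and it was modest and beyond the scatter: a 2.8-fold higher number from compound 1 to compound 2 (0.44 log units; beyond the scatter). Compound 3 again swaps methoxy for chloro, but in the reverse direction, so a modest step to a lower number is expected in this assay. For the measured compounds named here, no measured compound carries 2,3-dichlorophenyl, so this guide is loose. The expected change is a 2.8-fold lower number from compound 2 to compound 3 (0.45 log units; beyond the scatter). For compound 3 the estimated value is 11000 nM, within a range of 4000 nM to 28000 nM.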

Compound 3, half-maximal inhibitory concentration: 18500 nM
Compound 3: the middle estimate sits 1.7-fold (0.23 log units) below what was measured; the measured number falls inside the stated range.
By their numbers in this assay, from the lowest: compounds 1, 3 and 2 (each within the scatter of the next, the first and the last beyond it).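

The new group separates compound 3 from neither neighbour: 2,3-dichlorophenyl in place of 4-methoxyphenyl gives a 1.7-fold lower number from compound 2 to compound 3 (0.22 log units; within the scatter) in this assay, and 2,3-dichlorophenyl in place of 4-chlorophenyl gives a 1.7-fold higher number from compound 1 to compound 3 (0.22 log units; within the scatter) at the same double-bonded chain carbon. So while compound 1 and compound 2 lie beyond the scatter of each other, compound 3 cannot be told apart from either, and the chlorine-bearing compound 3 does not clearly join compound 1 as against compound 2. Nothing measured on these compounds accounts for this result.

The compounds shown leave open how an amine or a carboxylic acid on this aromatic ring would read in this assay. They also leave open whether a pyridine ring in its place would stay within the same narrow spread.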